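Chloro to trifluoromethyl in the piperazin-1-yl compound

This account rests on a few compounds, and the source may have more. Where it says the series, first, only, none or still open, it means among the compounds named here.

Among the measured compounds shown here, in a functional assay on V79 cells (Cricetulus griseus) for cytotoxicity, read by colony formation (a higher number here means a weaker inhibitor, a lower number a stronger inhibitor), compound 3 (`O=C(O)c1cn(C2CC2)c2c(Cl)c(N3CCNCC3)c(F)cc2c1=O`) gives 43 ug/mL, the lowest number so far and beyond the scatter from the other two. Compound 1 (`CCNCC1CCN(c2c(F)cc3c(=O)c(C(=O)O)cn(C4CC4)c3c2C(F)(F)F)C1`) gives 120 ug/mL, and compound 2 (`CNCC1(C)CCN(c2c(F)cc3c(=O)c(C(=O)O)cn(C4CC4)c3c2C(F)(F)F)C1`) gives 230 ug/mL.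

Compound 4 (`O=C(O)c1cn(C2CC2)c2c(C(F)(F)F)c(N3CCNCC3)c(F)cc2c1=O`) is the next comparison for compound 3: trifluoromethyl in place of chloro on an aromatic carbon. Trifluoromethyl takes the place of chloro on an aromatic carbon, ortho to a piperazin-1-yl group.

For the measured compounds named here, no measured step isolates this change. Going by the values given here, the only step available, a 1.9-fold higher number from compound 1 to compound 2 (0.28 log units; within the scatter), exchanges 3-((ethylamino)methyl)pyrrolidin-1-yl for 3-methyl-3-((methylamino)methyl)pyrrolidin-1-yl. Trifluoromethyl is present at both ends of that step, so it gives no direct reading on chloro against trifluoromethyl. Compound 1 and compound 2 do carry trifluoromethyl and both stand above compound 3, but they also carry pyrrolidin-1-yl groups instead of piperazin-1-yl. That gap therefore cannot be assigned to trifluoromethyl alone.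

Only a small upward step in this assay is expected, not clearly beyond the scatter, and this expectation rests on thin evidence. The expected step is a 1.7-fold higher number from compound 3 to compound 4 (0.24 log units; within the scatter). For compound 4 the estimate is 75 ug/mL, with an estimated range of 30 ug/mL to 190 ug/mL.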

Compound 4, half-maximal inhibitory concentration: 1650 ug/mL
Compound 4: middle estimate off by 22-fold (1.34 log units), on the low side, and the stated range ends below it.
By their numbers in this assay, from the lowest: compound 3; then compounds 1 and 2 (each within the scatter of the next); then compound 4.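

In this assay the exchange of chloro for trifluoromethyl on this aromatic carbon, ortho to a piperazin-1-yl group, now has a direct reading, and it is large: a 38-fold higher number from compound 3 to compound 4 (1.58 log units; beyond the scatter). With trifluoromethyl held in place, the amine group on the shared core also moves the number, with a 7.2-fold higher number from compound 2 to compound 4 (0.86 log units; beyond the scatter) and a 14-fold higher number from compound 1 to compound 4 (1.14 log units; beyond the scatter) on going to piperazin-1-yl, so the compounds carrying trifluoromethyl do not sit at one level. Compound 4 therefore has the highest number of the four and is the weakest inhibitor here, and the large chloro to trifluoromethyl step is so far known only with piperazin-1-yl present.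

The compounds shown leave open how a methyl or methoxy group on this aromatic carbon would stand against chloro and trifluoromethyl, and whether the step keeps its size with 3-((ethylamino)methyl)pyrrolidin-1-yl or 3-methyl-3-((methylamino)methyl)pyrrolidin-1-yl in place of piperazin-1-yl. Nothing available bears on the reason for the size of this step.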